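Half-life in rat: amino to methyl on the core

This account rests on a few compounds, and the source may have more. Where it says the series, first, only, none or still open, it means among the compounds named here.

Measured compounds:
compound 1 `CCCc1nc2c(C)cc(C)nc2n1Cc1ccc(-c2c(C(=O)O)c(N)nc3ccccc23)cc1`: 0.28 h
compound 2 `CCc1nc2c(C)cc(C)nc2n1Cc1ccc(-c2c(-c3nn[nH]n3)cnc3ccccc23)cc1`: 0.68 h

In an in vivo ADME assay on the whole organism (strain Sprague-Dawley) for metabolic stability, with Rattus norvegicus as the target, at a dose of 3 mg/kg by the intravenous route (on this read-out lower numbers stand for a shorter-lived compound and higher numbers for a longer-lived compound), compound 1 gives 0.28 h, the lowest of the two numbers; compound 2 gives 0.68 h, a gap beyond the scatter. Compound 3 `CCCc1nc2c(C)cc(C)nc2n1Cc1ccc(-c2c(C(=O)O)c(C)nc3ccccc23)cc1` is not yet measured and differs from compound 1 in one place: methyl in place of amino on an aromatic carbon. Within the data shown here, no measured pair shows this change. The step expected in this assay is small, toward a somewhat longer-lived compound at most, and may well stay within the scatter: a 1.3-fold higher number from compound 1 to compound 3 (0.10 log units; within the scatter). Compound 3 is therefore estimated at 0.35 h, with a range from 0.15 h to 0.8 h.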

Compound 3, half-life: 0.33 h
Compound 3: the middle estimate sits 1.1-fold (0.03 log units) above what was measured; the measured number falls inside the stated range.
By their numbers in this assay, from the lowest: compounds 1 and 3 (each within the scatter of the next); then compound 2.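

In this assay, methyl in place of amino on this aromatic carbon, next to the ring nitrogen and ortho to a carboxy group, gives a 1.2-fold higher number from compound 1 to compound 3 (0.07 log units; within the scatter), so the two compounds cannot be told apart on this read-out. At this position, the hydrogen-bond donor and acceptor counted on the amino group can go without a step beyond the scatter. Nothing at hand accounts for this result. Still open, going by these compounds, is whether a methoxy group or a trifluoromethyl group on this carbon would give a step beyond the scatter.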